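The compounds below may be only part of what the source reports. "The series", "measured", "known", "first", "only" and "open" are said of these compounds alone.

Of the compounds shown here, three sharing one core have been tested in an ADME assay on Raji cells (Homo sapiens) for cytotoxicity, with a stated time of 72 h; on this read-out higher numbers stand for an effect only at larger amounts of compound and lower numbers for an effect already at smaller amounts. Compound 1 `Cc1cc(NC(=O)Nc2ccc(C(=O)O)cc2)c2ccccc2n1` reaches only the assay limit, > 25000 nM. Compound 2 `Cc1cc(NC(=O)Nc2ccccc2F)c2ccccc2n1` likewise reaches only the assay limit, > 25000 nM. Among the measured compounds shown here, compound 3 `Cc1cc(NC(=O)Nc2cccc(Cl)c2)c2ccccc2n1` is the one member with a measured number, 18000 nM. On the numbers shown it is the only figure. For the measured compounds named here, the single measured step, an at least 1.3-fold lower number from compound 2 to compound 3 (0.14 log units; that floor lies within the scatter), cannot be sized beyond its floor, and that floor lies within the scatter. Two of the three values shown sit at the limit of > 25000 nM in this assay, at which 2 of the 3 values shown sit. Compound 4 `Cc1cc(NC(=O)Nc2ccc(F)cc2)c2ccccc2n1` differs from compound 3 as follows: 4-fluorophenyl in place of 3-chlorophenyl on an amide-type nitrogen. Going by the values given here, no measured step bears directly on this change, and the one step known gave nothing beyond the scatter. The step in this assay is thus expected to be a 1.4-fold higher number from compound 3 to compound 4 (0.14 log units; within the scatter), within the scatter. Compound 4 is therefore estimated at 25000 nM, with a range from 12000 nM to 60000 nM, and a renewed limit is expected to be quite possible.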

Compound 4, half-maximal effective concentration: > 25000 nM
Compound 4: no number, only a limit; the forecaster's own chance of this, stated with the estimate: 60%; the middle value sits exactly at the limit.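

In this assay, 4-fluorophenyl in place of 3-chlorophenyl on the amide-type nitrogen gives an at least 1.3-fold higher number from compound 3 to compound 4 (0.14 log units; that floor lies within the scatter), so this position now has a second step that cannot be sized beyond its floor, and that floor again lies within the scatter. The steps to compound 4 from compound 2 and from compound 1 join two limits and cannot be read. Compound 3 therefore remains the only member with a measured number, and the series offers little that can be compared: the limit of > 25000 nM in this assay, at which 3 of the 4 values shown sit.

From the compounds shown here alone, what a 3-fluorophenyl or a 4-chlorophenyl group would give on this nitrogen stays open, and with it whether the chlorine or its place accounts for compound 3 carrying a number. Also open, going by these compounds, is what an amine or a methoxy group on this aromatic ring would give.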